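Cytotoxicity notes: from compound 2 to compound 3

The compounds below may be only part of what the source reports. "The series", "measured", "known", "first", "only" and "open" are said of these compounds alone.

Of the compounds shown here, two have been read in a functional assay on HCT-116 cells (Homo sapiens) for cytotoxicity, read by MTT assay, with a stated time of 72 h (a higher number here means a weaker inhibitor, a lower number a stronger inhibitor), and neither returns a number. Compound 1 (`N[C@H]1CC[C@H](Nc2c(C(=O)NCc3ccc(F)cc3)nc(N3CCCCS3(=O)=O)c3cccnc23)CC1`) gives > 10000 nM as a limit of the assay. Compound 2 (`CS(=O)(=O)Oc1c(C(=O)NCc2ccc(F)cc2)nc(Br)c2cccnc12`) gives > 20000 nM as a limit as well. Compound 2 therefore stands only at a limit and offers no number to work from.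

Compound 3 (`Nc1cccc(Nc2c(C(=O)NCc3ccc(F)cc3)nc(Br)c3cccnc23)c1`) has (3-aminophenyl)amino in place of (methylsulfonyl)oxy on an aromatic carbon, para to a bromo group ((3-aminophenyl)amino in place of (methylsulfonyl)oxy on an aromatic carbon). Going by the values given here, no measured step covers this change, so the expectation is tentative. A moderate move toward stronger inhibition in this assay is expected, and a further reading at a limit would not surprise. The estimated step runs an at least 2.5-fold lower number from compound 2 to compound 3 (0.39 log units; beyond the scatter) and carries wide uncertainty. The expected value for compound 3 is 8000 nM with a range from 1500 nM to 30000 nM as estimated here.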

Compound 3, half-maximal inhibitory concentration: > 10000 nM
Compound 3: only a limit was reported; the forecaster's own chance of this, stated with the estimate: 45%; middle value at least 1.2-fold (0.09 log units) away from the limit.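

No step can be read from compound 2 to compound 3: both stand only at limits of this assay. The compounds shown leave open what number any of them would return in this assay, and whether (3-aminophenyl)amino in place of (methylsulfonyl)oxy shifts the reading at all.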